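The source may hold more compounds than are shown below. What is called first, only, known or untested is meant among the compounds shown, and "the series" means these compounds.

Measured so far in a functional assay on MCF7 cells (Homo sapiens) for inhibition, read by colorimetric assay and MTT assay, with a stated time of 72 h; on this read-out higher numbers stand for weaker inhibition and lower numbers for stronger inhibition:
- compound 1 `C=CCCCCOc1cc(F)ccc1-c1cnc(OCCC=C)n1C` gives 59000 nM
- compound 2 `C=CCCCCOc1ccccc1-c1cnc(OCCCCC=C)n1C` gives 5000 nM
- compound 3 `C=CCCCCOc1ncc(-c2ccccc2OC)n1C` gives 5000 nM

Compound 2 stands level with compound 3, and together they hold the lowest of the three numbers. Compound 1 has the clearly higher number, which means weaker inhibition.

The compound awaiting measurement is compound 4 `C=CCCCCOc1ccccc1-c1cnc(OC)n1C`. It differs from compound 2 by one change: hydrogen in place of pent-4-en-1-yl on a saturated chain carbon bound to an oxygen on an aromatic ring. Cut one bond further out, this reads as hex-5-en-1-yl to methyl.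

Compound 2 carries this chain in two places. The closest evidence is the same exchange made at the other place, which shows no change at the digits printed from compound 2 to compound 3 (within the scatter). That single step suggests the chain can be shortened to methyl without a shift in the number, although it was measured at a different place from the one changing now. A clean step cannot be read from compound 1 (59000 nM), which differs from compound 2 in more than one place, including the chain in question. The data therefore do not rule out a rise, so little or no step is expected, with more room upward than downward.

The estimate amounts to an expected 1.4-fold higher number from compound 2 to compound 4 (0.15 log units; within the scatter) in this assay. For compound 4 the estimated value is 7000 nM, with an expected range from 2500 nM to 25000 nM.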

Compound 4, half-maximal inhibitory concentration: 98000 nM
Compound 4: the middle estimate sits 14-fold (1.15 log units) below what was measured, and the stated range ends below it.
By their numbers in this assay, from the lowest: compounds 2 and 3 (each within the scatter of the next); then compounds 1 and 4 (each within the scatter of the next).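

In this assay, exchanging hex-5-en-1-yl for methyl at this place gives a 20-fold higher number from compound 2 to compound 4 (1.29 log units; beyond the scatter), whereas the same exchange at the other place that carries this chain gave no change at the digits printed from compound 2 to compound 3 (within the scatter). For the compounds shown here, the two chains of compound 2 are therefore not interchangeable: across these two pairs, the one at the place changed in compound 4 matters for the number, while the one changed in compound 3 can give way to methyl without a shift beyond the scatter. Nothing in the data at hand explains why the number rises at one place and not at the other.

As far as these compounds go, what the chain at this place contributes remains open, since only its full length and methyl can be compared directly, and the step to compound 1 cannot be read, as that compound also differs elsewhere. An ethyl chain, a saturated hexyl chain or a longer chain at this place could show whether the number depends on chain length or on the terminal double bond.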